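The compounds below may be only part of what the source reports. "The series", "measured", "known", "first", "only" and "open" are said of these compounds alone.

Working notes on the series. All numbers come from an assay for inhibition of inositol hexakisphosphate kinase 2 (Homo sapiens), read by colorimetric assay, coupled enzyme assay and malachite green, with a stated time of 120 min, in the presence of a further agent that is not named here; a higher number here means a weaker inhibitor, a lower number a stronger inhibitor. Compound 1 `O=C(O)c1ccc2noc(-c3ccc(-c4cccnc4)cc3)c2c1` gives 54 nM in this assay. Compound 2 `O=C(O)c1ccc2noc(-c3ccc(Cc4ccccc4)cc3)c2c1` gives 65 nM in this assay. Among the compounds with values here, the one measured single-point step, a 1.2-fold higher number from compound 1 to compound 2 (0.08 log units; within the scatter), lies within the scatter, so those two compounds are not separable on these numbers. Compound 3 `O=C1CCC(C(=O)Nc2ccc(-c3onc4ccc(C(=O)O)cc34)cc2)CN1` gives 2390 nM in this assay, the highest of the three numbers: its value stands well apart from both compound 2 and compound 1, and both gaps are beyond the scatter.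

Compound 4 `O=C(O)c1ccc2noc(-c3ccc(NC(=O)c4ccncn4)cc3)c2c1` has not yet been measured in this assay. The change from compound 3 is a group of 6 heavy atoms (4 carbon, 2 nitrogen; one six-membered aromatic ring with 2 hetero atoms) in place of a group of 7 heavy atoms (5 carbon, 1 nitrogen, 1 oxygen; one six-membered non-aromatic ring with 1 hetero atom), on a carbonyl carbon. The amide linkage of compound 3 is retained. Within the data shown here, the only measured step, a 1.2-fold higher number from compound 1 to compound 2 (0.08 log units; within the scatter), concerns a group on an aromatic carbon rather than on a carbonyl carbon, so it does not bear directly on this change; no measured pair exchanges the group on the carbonyl carbon. The expectation therefore rests on compound 3 alone, with its value 2390 nM as the anchor. The step of a 2.0-fold lower number from compound 3 to compound 4 (0.30 log units; within the scatter) is expected to be small, toward a lower number if anything, and not clearly beyond the scatter. Compound 4 is estimated at 1200 nM in this assay, within a range of 300 nM to 5000 nM.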

Compound 4, half-maximal inhibitory concentration: 720 nM
Estimate against measurement, compound 4: 1.7-fold (0.22 log units) above, and the stated range covers the measured number.
By their numbers in this assay, from the lowest: compounds 1 and 2 (each within the scatter of the next); then compound 4; then compound 3.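

On the carbonyl carbon whose other neighbour is the amide-type nitrogen, pyrimidin-4-yl in place of the non-aromatic ring group gives a 3.3-fold lower number from compound 3 to compound 4 (0.52 log units; beyond the scatter) in this assay, the first measured sign that the group at this place can move the number beyond the scatter. That movement recovers only part of the distance to the two compounds without the amide linkage: ((pyrimidin-4-yl)carbonyl)amino in place of benzyl on an aromatic carbon gives an 11-fold higher number from compound 2 to compound 4 (1.04 log units; beyond the scatter), and the same group in place of pyridin-3-yl gives a 13-fold higher number from compound 1 to compound 4 (1.12 log units; beyond the scatter), so both of these large steps remain in this assay. No measurement is available that explains these steps.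

The compounds shown leave open how the number responds to phenyl or pyridin-2-yl on the same carbonyl carbon, and therefore whether the lower number of compound 4 follows from an aromatic ring generally or from pyrimidin-4-yl in particular. They also leave open whether a simple amine or a longer chain on that aromatic carbon would stay near compound 4 or come closer to compound 1 and compound 2.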